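Dropping a Methyl from Compound 1: What to Expect

A few compounds are considered here, and "the series" means these few. Any claim that something is new, unique, unknown or untested is made for them only; others in the source may bear on it.

Measured so far:
Compound 1, `Cc1nnc(Sc2cc(NC(=O)c3ccc(Cl)cc3)c3ccccc3c2O)s1`, gives 8.48% in an assay on isolated protein for inhibition of RAC-alpha serine/threonine-protein kinase (Homo sapiens), read by fluorescence, with a stated time of 30 min, tested at 10 uM; on this read-out higher numbers stand for more inhibition at the one concentration tested (going by the name of the read-out) and lower numbers for less inhibition.
Compound 2, `O=C(Nc1cc(Sc2ncn[nH]2)c(O)c2ccccc12)c1ccc2ccccc2c1`, gives 41.6% in this assay.
Compound 3, `O=C(Nc1cc(Sc2ncn[nH]2)c(O)c2ccccc12)c1cccc(Cl)c1`, gives 46% in this assay.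

Among these three numbers compound 1 stands lowest; the gaps to compound 2 and to compound 3 are both beyond the scatter, so compound 1 has the lowest number of the three in this assay. Among the compounds with values here, the only single-point step measured is a number 4.4 percentage points higher from compound 2 to compound 3 (within the scatter), which concerns the group on the carbonyl carbon and is within the scatter.

Compound 4, `O=C(Nc1cc(Sc2nncs2)c(O)c2ccccc12)c1ccc(Cl)cc1`, has not yet been measured. It differs from compound 1 in one place: hydrogen in place of methyl on an aromatic carbon. Within the data shown here, no measured step touches this position, and compound 2 and compound 3 carry a different five-membered ring on the sulfur, so their values cannot be read as a guide to this change. Among the measured compounds shown here, what is known is that the one small change on a peripheral group, from compound 2 to compound 3, stayed within the scatter. Removing one carbon is a change of similar scale, so the expected step of a number 3.5 percentage points higher from compound 1 to compound 4 (within the scatter) is none beyond the scatter. Compound 4 is therefore estimated at 12%, within a range from 0% to 30%.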

Compound 4, a percentage reported as inhibition, at one concentration (the size of the read-out at that concentration, not a potency): 7.5%
Compound 4: the middle estimate sits 4.5 percentage points above what was measured; measured number inside the range.
By their numbers in this assay, from the lowest: compounds 4 and 1 (each within the scatter of the next); then compounds 2 and 3 (each within the scatter of the next).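

Going from methyl to hydrogen on an aromatic carbon of the five-membered ring gives a number 1 percentage points lower from compound 1 to compound 4 (within the scatter) in this assay, and this is the first measured step at this position. Taking the methyl away does not lift the number: compound 4 gives 7.5% at the one concentration tested, so the read-out stays low with either methyl or hydrogen on this carbon, and the 5-methyl-1,3,4-thiadiazol-2-yl and 1,3,4-thiadiazol-2-yl groups cannot be told apart here. Nothing measured here explains why this step is so small.

As far as these compounds go, only the smallest possible change at this carbon has been covered, so it remains open whether an amine, a carboxylic acid or a longer chain such as propyl there would move the number beyond the scatter. From the compounds shown here alone, it also remains open how much the ring on the sulfur matters on its own, since compound 2 and compound 3 differ from compound 1 and compound 4 in more than one place and so cannot settle that question.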